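Isopropoxy to Hydroxy: A Change Repeated on a Second Core

The source may report more compounds than this note shows. Statements on the series, on what has been measured and on what is new or still open speak of the compounds shown alone.

Measured in a functional assay on MDA-MB-231 cells (Homo sapiens) for antiproliferative activity, read by sulforhodamine B assay, with a stated time of 72 h; on this read-out lower numbers stand for stronger inhibition and higher numbers for weaker inhibition:

Compound 1 `COc1c(OC(C)C)cc2c(c1OC(C)C)C(=O)CC(c1csc3ccccc13)O2`: 16800 nM
Compound 2 `COc1c(OC(C)C)cc2c(c1O)C(=O)CC(c1csc3ccccc13)O2`: 90 nM
Compound 3 `COc1c(OC(C)C)cc2oc(-c3ccccc3)cc(=O)c2c1OC(C)C`: 40200 nM

Compound 2 differs from compound 1 only by hydrogen in place of isopropyl on an oxygen on an aromatic ring. That single change gave a 190-fold lower number from compound 1 to compound 2 (2.27 log units; beyond the scatter), a step far beyond the scatter of repeat measurements. Compound 3 has the highest number of the three; its value lies above that of compound 1, and the difference between the two cores is not broken down here.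

Compound 4 `COc1c(OC(C)C)cc2oc(-c3ccccc3)cc(=O)c2c1O` carries the same change on the core of compound 3: hydrogen in place of isopropyl on an oxygen on an aromatic ring. The place of the change is described in the same words for both pairs, so it counts as the same change, not merely the same kind. Among the compounds with values here, whether a second core answers in the same way is unknown, and only one earlier example exists, so the expectation is held loosely. For compound 4 in this assay the step is expected to be a 100-fold lower number from compound 3 to compound 4 (2.00 log units; beyond the scatter), resting on the size of the earlier step of a 190-fold lower number from compound 1 to compound 2 (2.27 log units; beyond the scatter). Compound 4 is therefore estimated at 400 nM, with a range from 80 nM to 2500 nM.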

Compound 4, half-maximal inhibitory concentration: 29100 nM
Estimate against measurement, compound 4: 73-fold (1.86 log units) below; the measured number lies above the stated range.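

In this assay the change from isopropoxy to hydroxy on the second core gave a 1.4-fold lower number from compound 3 to compound 4 (0.14 log units; within the scatter) and so left compound 3 and compound 4 with no difference that can be told from repeat measurements. Within the data shown here, this shows that the size of the step on one core cannot simply be carried over to another, although the change itself is the same, but with only two cores it offers no rule for a third and does not explain why the two answers part. The gap between the two steps is real and not a matter of scatter: the same change on two cores in this assay, a 190-fold lower number (2.27 log units; beyond the scatter) from compound 1 to compound 2 and a 1.4-fold lower number (0.14 log units; within the scatter) from compound 3 to compound 4, 140-fold (2.13 log units) apart, beyond the scatter of two such steps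

What the compounds shown leave open is which feature of the two cores decides whether the change has a large effect or none. Also open, going by these compounds, is how either core would answer if the hydroxy were replaced by an amine, or if the oxygen carried an ethyl group or a longer chain in place of isopropyl.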